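The compounds below may be only part of what the source reports. "The series", "measured", "known", "first", "only" and "open" are said of these compounds alone.

Of the compounds shown here, three have so far been measured in a physicochemical assay for lipophilicity; on this read-out lower numbers stand for lower lipophilicity and higher numbers for higher lipophilicity. Compound 1 `CN(C)c1ccc(/C=C2\CCC/C(=C\c3ccccc3[N+](=O)[O-])C2=O)cc1` gives 4.86. Compound 2 `O=C1/C(=C/c2ccccc2)CCC/C1=C\c1cccc([N+](=O)[O-])c1` gives 5.06. Compound 3 `O=C1/C(=C/c2ccc(F)cc2)CCC/C1=C\c1ccc([N+](=O)[O-])cc1` gives 5.08. Among these three numbers compound 2 stands second highest; its nearest neighbour is compound 3 and its furthest is compound 1, yet both gaps fall within the usual scatter of this assay, so the three measured compounds cannot be told apart on this read-out.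

Compound 4 `O=C1/C(=C/c2ccc(Cl)cc2)CCC/C1=C\c1cccc([N+](=O)[O-])c1` has not yet been measured. It differs from compound 2 in one place: chloro in place of hydrogen on an aromatic carbon. Among the measured compounds shown here, no measured pair shows this same change, so the size of its effect in this assay has to be estimated rather than read off. The expected step, a number 0.59 log units higher from compound 2 to compound 4 (beyond the scatter), is an increase that goes beyond the scatter. Compound 4 is therefore estimated at 5.65, with a range from 5.3 to 6.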

Compound 4, partition coefficient: 5.06
For compound 4 the middle estimate is 0.59 log units above the measured one, outside the stated range (below it).
By their numbers in this assay, from the lowest: compounds 1, 2, 4 and 3 (each within the scatter of the next).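

The swap of phenyl for 4-chlorophenyl now has its first direct reading in this assay, with no change at the digits printed from compound 2 to compound 4 (within the scatter). Among the compounds shown here, at this position on the shared core, chloro in place of hydrogen therefore does not separate the two compounds on this read-out, something the earlier compounds could not show, since no two of them differed in only one place. Nothing at hand offers a reason for this result.

This is a single pair, so it cannot say whether chloro would read the same on another aromatic carbon or on a different core. Nor do the compounds shown tell how a different group at this position, such as an amine, a carboxylic acid or a longer chain, would read in this assay.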